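This account rests on a few compounds, and the source may have more. Where it says the series, first, only, none or still open, it means among the compounds named here.

Measured compounds:
compound 1, `Cc1cc(Oc2ccc(OCc3ccccc3)cc2)nc(Nc2ccc(C#N)cc2)n1`, 27700 nM
compound 2, `COCCc1ccc(Oc2cc(C)nc(Nc3ccc(C#N)cc3)n2)cc1`, 13800 nM
compound 3, `Cc1cnc(Nc2ccc(C#N)cc2)nc1Oc1ccc(OCc2ccccc2)cc1`, 170000 nM

These three compounds were tested in an ADME assay on MT4 cells (Homo sapiens) for cytotoxicity, read by MTT assay, with a stated time of 5 days; on this read-out lower numbers stand for higher toxicity in this test and higher numbers for lower toxicity in this test. Compound 1 and compound 2 share one core and differ in a single place: 2-methoxyethyl in place of benzyloxy on an aromatic carbon. The step of a 2.0-fold lower number from compound 1 to compound 2 (0.30 log units; within the scatter), so on this read-out the two compounds cannot be told apart with confidence.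

Compound 3 is built from the same atoms as compound 1, but they are joined differently; how its core differs from that of compound 1 is not broken down here. In this assay compound 3 gives the highest of the three numbers, and its distance from both compound 1 and compound 2 lies beyond the usual scatter.

Compound 4, `COCCc1ccc(Oc2nc(Nc3ccc(C#N)cc3)ncc2C)cc1`, is not yet measured. It stands to compound 3 as compound 2 stands to compound 1, carrying the same change: 2-methoxyethyl in place of benzyloxy on an aromatic carbon. Among the compounds with values here, because the earlier step of a 2.0-fold lower number from compound 1 to compound 2 (0.30 log units; within the scatter) stayed within the scatter, the step from compound 3 to compound 4 is expected to be of similar small size, a 1.7-fold lower number from compound 3 to compound 4 (0.23 log units; within the scatter), though with only one prior example this rests on thin ground. In this assay compound 4 is therefore estimated at 100000 nM, with a plausible range from 40000 nM to 250000 nM.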

Compound 4, half-maximal cytotoxic concentration: > 346000 nM
Compound 4: no number, only a limit; the forecaster's own chance of this, stated with the estimate: 25%; middle value at least 3.4-fold (0.53 log units) away from the limit.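

In this assay compound 4 reaches only a limit of the assay, not an exact number: the limit of > 346000 nM in this assay, at which 1 of the 4 values shown sits. Even with that limit, the swap of benzyloxy for 2-methoxyethyl gives an at least 2.0-fold higher number from compound 3 to compound 4 (0.30 log units; that floor lies within the scatter), and this step does not match the one made on the other core: the same change on two cores in this assay, a 2.0-fold lower number (0.30 log units; within the scatter) from compound 1 to compound 2 and an at least 2.0-fold higher number (0.30 log units; that floor lies within the scatter) from compound 3 to compound 4, at least 4.0-fold (0.61 log units) apart, beyond the scatter of two such steps. The small step seen on the core of compound 1 therefore could not simply be carried over to the core of compound 3, although one pair on each core, with one end left open, shows neither the true size of the second step nor why the two cores part ways.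

The compounds shown carry only benzyloxy and 2-methoxyethyl at this place, so it remains open how another group there, such as an amine, a carboxylic acid or a longer chain, would read on either core. As far as these compounds go, it also remains open whether the same swap on a further core would follow the step seen with compound 1 and compound 2, the step seen with compound 3 and compound 4, or neither.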